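Swapping a two-ring amide for diisobutylamino

This account rests on a few compounds, and the source may have more. Where it says the series, first, only, none or still open, it means among the compounds named here.

Compound 3 `Cc1cccc(N(C)c2cc(Nc3cccc(C(=O)N4CCCC5CCCCC54)c3)ncn2)c1` carries an amide on one of its aromatic rings. In an assay on isolated protein for inhibition of vascular endothelial growth factor receptor 1 (Homo sapiens), read by HTRF, tested at 10 uM (a higher number here means more inhibition at the concentration tested (going by the name of the read-out), a lower number less inhibition), compound 3 gives 8%, the highest of the three numbers, yet both other values lie within the usual scatter of it: compound 1 `COC[C@@H]1CCCN1C(=O)[C@@H]1CCCN1c1cc(Nc2cccc(OC)c2)nc(N)n1` gives 3% and compound 2 `COC(=O)C(CO)NC(=O)[C@@H]1CCCN1c1nccc(Oc2cccc(C)c2)n1` gives 0%, so no order among the three can be read. Compound 4 `Cc1cccc(N(C)c2cc(Nc3cccc(C(=O)N(CC(C)C)CC(C)C)c3)ncn2)c1` keeps the rest of compound 3 and changes only the amide: a group of 9 heavy atoms (8 carbon, 1 nitrogen; no ring) in place of a group of 10 heavy atoms (9 carbon, 1 nitrogen; one six-membered non-aromatic ring of carbon only, one six-membered non-aromatic ring with 1 hetero atom), on a carbonyl carbon. Going by the values given here, no pair of measured compounds differing in a single place exists here, so nothing shows how such a swap moves this assay. All three numbers sit near the bottom of the scale, and the step is expected to stay within the scatter: a number 3 percentage points lower from compound 3 to compound 4 (within the scatter). Compound 4 is estimated at 5%, expected between -5% and 15%.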

Compound 4, a percentage reported as inhibition, at one concentration (the size of the read-out at that concentration, not a potency): 5%
Estimate against measurement, compound 4: no gap at the digits printed; measured number inside the range.
By their numbers in this assay, from the lowest: compounds 2, 1, 4 and 3 (each within the scatter of the next).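

In this assay, the first pair differing in a single place gives a number 3 percentage points lower from compound 3 to compound 4 (within the scatter), so the two-ring amide and diisobutylamino on this carbonyl carbon cannot be told apart. Both compounds stay near the bottom of the scale, so a group with no ring serves here as well as one with two rings. Nothing measured here offers an explanation for this result.

Still open, going by these compounds, is whether any group at this place can raise the number well beyond the scatter. A piperazine ring or a chain ending in a carboxylic acid, for example, could test this.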